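The source may report more compounds than this note shows. Statements on the series, on what has been measured and on what is new or still open speak of the compounds shown alone.

Working notes on the series, read in a functional assay on MGC-803 cells (Homo sapiens) for inhibition, read by MTT assay, with a stated time of 72 h; a lower number here means a stronger inhibitor, a higher number a weaker inhibitor. Compound 1 (`CC(C)c1ccc(NC(=O)C2CCN(C/C=C/c3ccccc3)CC2)cc1`) gives 5200 nM, and compound 2 (`N#Cc1ccc(NC(=O)C2CCN(C/C=C/c3ccccc3)CC2)cc1`) gives 28200 nM, the higher of the two numbers and so the weaker of this pair. Next comes compound 3 (`CN1CCN(c2ccc(NC(=O)C3CCN(C/C=C/c4ccccc4)CC3)cc2)CC1`), with this change from compound 2: 4-methylpiperazin-1-yl in place of cyano on an aromatic carbon. Among the measured compounds shown here, the only measured step that bears on it is a 5.4-fold higher number from compound 1 to compound 2 (0.73 log units; beyond the scatter), a modest step beyond the scatter, in which cyano came with the higher number. For the measured compounds named here, no measured compound carries a 4-methylpiperazin-1-yl group, so this guide is thin. Starting from compound 2 at 28200 nM, a modest move to a lower number is expected once cyano leaves, of about the size of that one measured step. The expected change is a 3.5-fold lower number from compound 2 to compound 3 (0.55 log units; beyond the scatter). In this assay the estimate for compound 3 is 8000 nM, with an expected range of 2500 nM to 25000 nM.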

Compound 3, half-maximal inhibitory concentration: 14000 nM
For compound 3 the middle estimate is 1.8-fold (0.24 log units) below the measured one, and the stated range covers the measured number.
By their numbers in this assay, from the lowest: compound 1; then compounds 3 and 2 (each within the scatter of the next).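

At this aromatic carbon, 4-methylpiperazin-1-yl in place of cyano gives a 2.0-fold lower number from compound 2 to compound 3 (0.30 log units; within the scatter) in this assay and so does not separate these two groups, even though they differ widely in size and one brings a non-aromatic ring. Among the compounds shown here, the same group in place of isopropyl gives a 2.7-fold higher number from compound 1 to compound 3 (0.43 log units; beyond the scatter) and leaves compound 1 as the strongest inhibitor of the three, with isopropyl the only one of these groups whose number stands apart from both others. No measurement on hand accounts for this order.

Three groups at one carbon cannot show whether the lower number belongs to alkyl groups generally or to isopropyl alone, and an ethyl or tert-butyl group would test this. On these data alone, a methoxy group or a primary amine at the same carbon also remains open, as does the piperazine without its methyl.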